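Amide aryl variation in the dimethoxy series: toward compound 4

The compounds below may be only part of what the source reports. "The series", "measured", "known", "first", "only" and "open" are said of these compounds alone.

Compound 1 `COc1cc2c(cc1OC)C(CC(=O)Nc1ccc(Br)cc1)CC2` gives 40.6% in a functional assay on the whole organism (strain Wistar) for inhibition, with Rattus norvegicus as the target, read by paw edema, with a stated time of 4 h, at a dose of 100 mg/kg; a higher number here means more inhibition at the dose given (going by the name of the read-out), a lower number less inhibition.
Compound 2 `COc1cc2c(cc1OC)C(CC(=O)Nc1ccccc1C)CC2` gives 25% in this assay.
Compound 3 `COc1cc2c(cc1OC)C(CC(=O)Nc1ccc(C)cc1)CC2` gives 32.8% in this assay.

On the numbers, compound 3 sits between the other two, but neither gap separates it: a number 7.8 percentage points lower from compound 1 to compound 3 (within the scatter) and a number 7.8 percentage points higher from compound 2 to compound 3 (within the scatter) are both within the scatter. Among the compounds with values here, the only step in the set that goes beyond the scatter is a number 15.6 percentage points lower from compound 1 to compound 2 (beyond the scatter), a modest one.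

The next compound is compound 4 `COc1cc2c(cc1OC)C(CC(=O)Nc1cccnc1)CC2`, which differs from compound 3 by pyridin-3-yl in place of 4-methylphenyl on an amide-type nitrogen.

Every measured step alters the group on the amide nitrogen, so all three bear on this change in kind, though none exchanges a carbon-only ring for a ring with one nitrogen. Two of them stayed within the scatter and the third was modest, so the expected step in this assay is one within the scatter, with no direction favoured and a wide range to cover the unknown ring nitrogen: a number 2.8 percentage points lower from compound 3 to compound 4 (within the scatter). Compound 4 is therefore estimated at 30%, between 15% and 45%.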

Compound 4, a percentage reported as inhibition, in the whole organism at one dose (the size of the read-out at that dose, not a potency): 34.4%
The estimate for compound 4 lay 4.4 percentage points below the measured number; the range from low to high includes it.
By their numbers in this assay, from the lowest: compounds 2, 3, 4 and 1 (each within the scatter of the next, the first and the last beyond it).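

Pyridin-3-yl is the first ring on the amide-type nitrogen that carries a hetero atom, and in this assay the exchange for 4-methylphenyl gives no separable change (a number 1.6 percentage points higher from compound 3 to compound 4 (within the scatter)). Compound 4 is also within the scatter of the two other aryl amides, with a number 9.4 percentage points higher from compound 2 to compound 4 (within the scatter) and a number 6.2 percentage points lower from compound 1 to compound 4 (within the scatter), so at this position the ring nitrogen adds no step beyond the scatter against any compound in the set. No available evidence accounts for this result.

Open, going by these compounds, is whether pyridin-2-yl or pyridin-4-yl would read like pyridin-3-yl, and whether an aromatic ring is needed here at all, a question that cyclohexyl or an n-butyl chain on the amide-type nitrogen would address. Potency also stays open, since each compound is read at a single dose.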